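The source may report more compounds than this note shows. Statements on the series, on what has been measured and on what is new or still open speak of the compounds shown alone.

Working notes on the series. Of the compounds shown here, two have a number so far. Compound 1 `CC(Oc1cccnc1Nc1cnn(C)c1)c1cccc(C(=O)NCc2ccccc2S(=O)(=O)C(C)C)c1` gives, in a functional assay on HCC78 cells (Homo sapiens) for antiproliferative activity, read by MTT assay, with a stated time of 48 h (on this read-out higher numbers stand for weaker inhibition and lower numbers for stronger inhibition), 63100 nM. Compound 2 `Cc1ccc(CNC(=O)c2cccc(C(C)Oc3ccnc(NN4CCOCC4)c3)c2)cc1` gives in this assay 68300 nM. The two numbers sit within the usual scatter of each other, so neither compound can be set apart from the other on this read-out; both sit in a weak region.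

Compound 3 `COc1cc(Nc2cc(OC(C)c3cccc(C(=O)NCc4ccc(C)cc4)c3)ccn2)cc(OC)c1OC` has not yet been measured. It differs from compound 2 in one place: 3,4,5-trimethoxyphenyl in place of morpholin-4-yl on a nitrogen on an aromatic ring. Going by the values given here, no measured pair shows this change, so there is no step to lean on. Given that compound 2 gives 68300 nM, the expectation for compound 3 is a move to a lower number, of a size beyond the scatter, expressed as the step of a 2.7-fold lower number from compound 2 to compound 3 (0.44 log units; beyond the scatter). The estimate for compound 3 in this assay is 25000 nM, with a range from 4000 nM to 100000 nM.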

Compound 3, half-maximal inhibitory concentration: 15700 nM
Beside the measured number, compound 3's estimate is 1.6-fold (0.20 log units) above it, and the stated range covers the measured number.
By their numbers in this assay, from the lowest: compound 3; then compounds 1 and 2 (each within the scatter of the next).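

Going by these compounds alone, on a nitrogen on an aromatic ring, 3,4,5-trimethoxyphenyl in place of morpholin-4-yl gives a 4.4-fold lower number from compound 2 to compound 3 (0.64 log units; beyond the scatter) in this assay, a modest step but the only one so far, and it lies beyond the scatter. This place therefore responds to the group it carries, which compounds 1 and 2, within the scatter of each other and differing in more than one place, could not show. The change replaces a non-aromatic ring with 2 hetero atoms by an aromatic ring of carbon only, and no measurement at hand gives a reason for the step.

On these data alone, what stays open is whether the three methoxy groups matter or the aromatic ring alone carries the step, a question that a plain phenyl on this nitrogen would answer. As far as these compounds go, whether the same change would hold on the core of compound 1 also stays open.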